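Moving the carboxylic acid and adding fluorine on the end ring

The source may hold more compounds than are shown below. What is called first, only, known or untested is meant among the compounds shown, and "the series" means these compounds.

Measured so far:
- compound 1, `Cc1ncc(OCCCCOc2ccc(C(=O)CC(C)(C)C)c(O)c2C)cc1C(=O)O`, 28 nM
- compound 2, `Cc1ccc(OCCCCOc2ccc(C(=O)CC(C)(C)C)c(O)c2C)cc1C(=O)O`, 210 nM
- compound 3, `COc1ccc(OCCCCOc2ccc(C(=O)CC(C)(C)C)c(O)c2C)cc1C(=O)O`, 13 nM

In an assay for positive allosteric modulation of metabotropic glutamate receptor 2 (Rattus norvegicus) (on this read-out lower numbers stand for an effect already at smaller amounts and higher numbers for an effect only at larger amounts of compound), compound 2 gives the highest number of the three. Compound 1 sits nearer, with a 7.5-fold higher number from compound 1 to compound 2 (0.88 log units; beyond the scatter); compound 3 is furthest away, with a 16-fold lower number from compound 2 to compound 3 (1.21 log units; beyond the scatter). Both of these steps touch only the ring at the far end of the chain, the part that compound 4, `Cc1c(OCCCCOc2ccc(C(=O)O)cc2F)ccc(C(=O)CC(C)(C)C)c1O`, also changes: 4-carboxy-2-fluorophenyl in place of 3-carboxy-4-methylphenyl on an oxygen on a saturated carbon.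

Both known steps bear on the new one. Each shows that a small change to this end ring moves this assay by a clear amount, and from compound 2 every such change so far has lowered the number. Among the compounds with values here, the change to compound 4 is different in kind, since the carboxylic acid shifts its place and fluorine replaces the methyl, so no step matches it directly. The expectation is therefore a drop of moderate size, a 2.3-fold lower number from compound 2 to compound 4 (0.37 log units; beyond the scatter), with wide uncertainty. Compound 4 is estimated at 90 nM, expected to fall between 20 nM and 500 nM.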

Compound 4, half-maximal effective concentration: 75 nM
Beside the measured number, compound 4's estimate is 1.2-fold (0.08 log units) above it, within the range that was stated.
By their numbers in this assay, from the lowest: compound 3; then compound 1; then compound 4; then compound 2.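

In this assay the end ring still works with its carboxylic acid moved and fluorine in place of the methyl: the switch to 4-carboxy-2-fluorophenyl gives a 2.8-fold lower number from compound 2 to compound 4 (0.45 log units; beyond the scatter) as a clear but modest gain. That gain is much smaller than the one methoxy brings, which is a 16-fold lower number from compound 2 to compound 3 (1.21 log units; beyond the scatter) for a single swap on the same ring. The new ring also falls short of the 5-carboxy-6-methylpyridin-3-yl ring, with a 2.7-fold higher number from compound 1 to compound 4 (0.43 log units; beyond the scatter) showing that this change does not recover the level of the pyridine-bearing compound.

As far as these compounds go, the moved acid and the fluorine arrive together, so their separate shares in the step remain open, as does the effect of a chlorine in place of the fluorine or an amide in place of the acid. Nothing available explains why the number moves as it does.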